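Alkynyl uracil series: antiproliferative notes on MCF7 cells

A few compounds are considered here, and "the series" means these few. Any claim that something is new, unique, unknown or untested is made for them only; others in the source may bear on it.

Measured compounds:
compound 1, `CCCCCCCCC#Cc1cn(CCC(COC(C)=O)COC(C)=O)c(=O)n(C(=O)c2ccccc2)c1=O`, gives 28900 nM;
compound 2, `CC(=O)OCC(CCn1cc(C#CCCCCl)c(=O)n(C(=O)c2ccccc2)c1=O)COC(C)=O`, gives 21000 nM;
compound 3, `CCCCCCCCC#Cc1cn(CCC(CO)CO)c(=O)[nH]c1=O`, gives 40300 nM.

All three numbers come from a functional assay on MCF7 cells (Homo sapiens) for antiproliferative activity, read by MTT assay, with a stated time of 72 h (on this read-out lower numbers stand for stronger inhibition and higher numbers for weaker inhibition), and each pair of them lies within the usual scatter of that read-out, so no order among the three is claimed. Compound 1 and compound 2 share one core and differ only in chloro in place of pentyl on a saturated chain carbon, three bonds along the chain from a triple-bonded carbon; the step of a 1.4-fold lower number from compound 1 to compound 2 (0.14 log units; within the scatter). Compound 3 stands on a second core; the difference between the cores of compound 1 and compound 3 is not broken down here.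

Compound 4, `O=c1[nH]c(=O)n(CCC(CO)CO)cc1C#CCCCCl`, has not yet been measured. Against compound 3 it shows (chloro in place of pentyl on a saturated chain carbon, three bonds along the chain from a triple-bonded carbon), the same change that separates compound 2 from compound 1, at the same place on the chain. The expected step of a 1.4-fold lower number from compound 3 to compound 4 (0.14 log units; within the scatter) rests on the measured step of a 1.4-fold lower number from compound 1 to compound 2 (0.14 log units; within the scatter) on the other core. On that basis compound 4 is expected to give about 29000 nM in this assay, with a plausible span from 14000 nM to 60000 nM.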

Compound 4, half-maximal inhibitory concentration: 35200 nM
For compound 4 the middle estimate is 1.2-fold (0.08 log units) below the measured one, within the range that was stated.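

Chloro in place of pentyl on a saturated chain carbon, three bonds along the chain from a triple-bonded carbon, gives in this assay a 1.1-fold lower number from compound 3 to compound 4 (0.06 log units; within the scatter) on the core of compound 3 . Set beside the same change on the core of compound 1, the step carries over with no difference that can be told from the noise: the same change on two cores in this assay, a 1.4-fold lower number (0.14 log units; within the scatter) from compound 1 to compound 2 and a 1.1-fold lower number (0.06 log units; within the scatter) from compound 3 to compound 4, 1.2-fold (0.08 log units) apart, within the scatter of two such steps. This shows that the two cores agree for this change, but since both steps lie within the scatter, it does not show that the change moves the read-out on either core, so the agreement is one between two null steps and not a transferable gain.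

On these data alone, an amine, a carboxylic acid or a nitrile at the end of this chain remains open, as does a longer chain, and any of these might give a step large enough to test transfer between the cores. As far as these compounds go, how the change behaves on any core beyond these two also stays open.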